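The source may report more compounds than this note shows. Statements on the series, on what has been measured and on what is new or still open speak of the compounds shown alone.

Within the data shown here, in a functional assay on K562 cells (Homo sapiens) for cytotoxicity, read by MTT assay (a lower number here means a stronger inhibitor, a higher number a weaker inhibitor), compound 3 `CCCCC(=O)Oc1cc(/C=C/C(=O)c2ccc(OC)c3c2OC(C)(C)C=C3)ccc1OC` gives 240 nM, the lower of the two actual numbers so far. Compound 2 `COc1ccc(/C=C/C(=O)c2ccc(OC)c3c2OC(C)(C)C=C3)cc1OCCCN(C)C` gives 2920 nM. For compound 1 `C=CCOc1cc(/C=C/C(=O)c2ccc(OC)c3c2OC(C)(C)C=C3)ccc1OC` the assay reports only a limit, > 10000 nM. Both measured changes to butylcarbonyl on the oxygen were large: an at least 41-fold lower number from compound 1 to compound 3 (1.61 log units; beyond the scatter) and a 12-fold lower number from compound 2 to compound 3 (1.09 log units; beyond the scatter). Compound 4 `COc1ccc(/C=C/C(=O)c2ccc(OC)c3c2OC(C)(C)C=C3)cc1OC(=O)CCl` keeps a carbonyl group at that place and differs only in its chain: chloro in place of propyl on a saturated chain carbon bound to a carbonyl carbon. In words, this is chloro in place of propyl on a saturated chain carbon bound to a carbonyl carbon. Among the measured compounds shown here, no measured step alters this chain, so no change beyond the scatter is expected, and the direction stays open. The expected step is a 1.7-fold higher number from compound 3 to compound 4 (0.22 log units; within the scatter). Compound 4 is estimated at 400 nM, with an expected range from 100 nM to 2000 nM.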

Compound 4, half-maximal inhibitory concentration: 400 nM
The estimate for compound 4 equals the measured number at the digits printed; low and high end bracket the measured number.
By their numbers in this assay, from the lowest: compounds 3 and 4 (each within the scatter of the next); then compound 2. At a limit, above all of these: compound 1.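

In this assay, the chain on the carbonyl can change from butyl to chloromethyl with no change beyond the scatter (a 1.7-fold higher number from compound 3 to compound 4 (0.22 log units; within the scatter)), so the low number does not depend on butyl alone. The second carbonyl compound also keeps a clear margin over the 3-(dimethylamino)propyl group on that oxygen (a 7.3-fold lower number from compound 2 to compound 4 (0.86 log units; beyond the scatter)). Compound 1 is reported only as a limit, so the step from its allyl group (an at least 25-fold lower number from compound 1 to compound 4 (1.39 log units; beyond the scatter)) gives only a bound on the size: the limit of > 10000 nM in this assay, at which 1 of the 4 values shown sits.

From the compounds shown here alone, whether a plain methyl, a longer chain or a chain ending in a carboxylic acid on the carbonyl would keep this level stays open.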